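The source may hold more compounds than are shown below. What is called first, only, known or untested is meant among the compounds shown, and "the series" means these compounds.

In a functional assay on PC-12 cells (Rattus norvegicus) for inhibition, read by sulforhodamine B assay (on this read-out higher numbers stand for weaker inhibition and lower numbers for stronger inhibition), compound 2, `COc1ccc(CC2SC(=O)NC2=O)cc1`, gives > 100000 nM, which is a limit and not a number. Compound 1, `O=C1NC(=O)C(Cc2ccc(OCC3CC3)cc2)S1`, gives > 100000 nM, which is also a limit. Among the compounds with values here, the series so far therefore rests on (the limit of > 100000 nM in this assay, at which 2 of the 2 values shown sit), and compound 2 has no measured potency from which to count a step.

Compound 3, `O=C1NC(=O)C(Cc2ccc(OCc3ccccc3)cc2)S1`, is the next to be read. The change from compound 2 is phenyl in place of hydrogen on a saturated chain carbon bound to an oxygen on an aromatic ring. In words, this is phenyl in place of hydrogen on a saturated chain carbon bound to an oxygen on an aromatic ring, or methyl to benzyl when cut one bond further out.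

Within the data shown here, the only measured step at this place is a step that the two limits leave unreadable from compound 1 to compound 2, and it gives no size or direction to carry over. Among the measured compounds shown here, with that step as the sole guide, the working expectation is that this assay stays near its limit, with no shift beyond the scatter expected and another limit the likeliest report. The expected change is a number no higher from compound 2 to compound 3 (the limit leaves the size open). The estimate for compound 3 is 100000 nM, with an expected range from 40000 nM to 200000 nM.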

Compound 3, half-maximal inhibitory concentration: > 100000 nM
Compound 3: only a limit was reported (the forecaster's own chance of this, stated with the estimate: 75%); the middle value sits exactly at the limit.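

In this assay compound 3 gives > 100000 nM as a limit and not a number. Within the data shown here, no step from compound 1 or compound 2 to compound 3 can be read, and the series still rests on a single limit: the limit of > 100000 nM in this assay, at which 3 of the 3 values shown sit.

The compounds shown leave open whether in this assay any group at this place gives a measurable potency on the shared core.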